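Removing a ring hydroxy from a glycoside lactone

A few compounds are considered here, and "the series" means these few. Any claim that something is new, unique, unknown or untested is made for them only; others in the source may bear on it.

Three glycoside lactones have been measured in a functional assay on BV-2 cells (Mus musculus) for inhibition, read by Griess assay, with a stated time of 24 h; a lower number here means a stronger inhibitor, a higher number a weaker inhibitor. Compound 1 `C[C@]12CCC[C@](C)(C(=O)O[C@@H]3O[C@H](CO)[C@@H](O)[C@H](O)[C@H]3O)[C@@H]1CC[C@@](C)(O)[C@@H]2CCC1=CCOC1=O` gives 402000 nM, compound 2 `C=C1CC[C@@H]2[C@](C)(CC[C@H](O)[C@]2(C)C(=O)O[C@@H]2O[C@H](CO)[C@@H](O)[C@H](O)[C@H]2O)[C@H]1CCC1=CCOC1=O` gives 68800 nM, and compound 3 `C=C1CC[C@@H]2[C@](C)(CCC[C@]2(O)C(=O)O[C@@H]2O[C@H](CO)[C@@H](O)[C@H](O)[C@H]2O)[C@H]1CCC1=CCOC1=O` gives 51600 nM. Compound 2 thus has the second highest of the three numbers; it sits within the scatter of compound 3 and well beyond the scatter of compound 1, which has the markedly higher number.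

Compound 4 `C=C1CC[C@@H]2[C@](C)(CCC[C@]2(C)C(=O)O[C@@H]2O[C@H](CO)[C@@H](O)[C@H](O)[C@H]2O)[C@H]1CCC1=CCOC1=O` has not yet been measured in this assay. It differs from compound 2 by one change: hydrogen in place of hydroxy on a saturated ring carbon. Within the data shown here, no pair of measured compounds shows this same change, so the size of the step is open. Since compound 2 and compound 3 give numbers within the scatter of each other although their hydroxy groups sit on different ring carbons, the hydroxy at this place does not appear decisive, and a step from compound 2 to compound 4 of a 1.2-fold higher number from compound 2 to compound 4 (0.07 log units; within the scatter) is expected, meaning no change beyond the scatter in either direction. Compound 4 is therefore estimated at 80000 nM, with a range from 30000 nM to 220000 nM.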

Compound 4, half-maximal inhibitory concentration: 65800 nM
Estimate against measurement, compound 4: 1.2-fold (0.08 log units) above; the measured number falls inside the stated range.
By their numbers in this assay, from the lowest: compounds 3, 4 and 2 (each within the scatter of the next); then compound 1.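

In this assay, the step on taking the hydroxy away is a 1.0-fold lower number from compound 2 to compound 4 (0.02 log units; within the scatter), so at this saturated ring carbon hydrogen and hydroxy cannot be told apart. The second comparison, methyl in place of hydroxy on a saturated ring carbon, gives a 1.3-fold higher number from compound 3 to compound 4 (0.11 log units; within the scatter), which shows that compound 4 stays within the scatter of both hydroxy compounds while carrying neither of their ring hydroxy groups. Nothing available here explains why the number holds when either hydroxy is lost.

On these data alone, only hydrogen and hydroxy are seen at this ring carbon, so it remains open whether an amine, a carboxylic acid or a longer chain there would move the number. This change also leaves open what sets compound 1 apart from the other three.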